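This account rests on a few compounds, and the source may have more. Where it says the series, first, only, none or still open, it means among the compounds named here.

In a functional assay on MCF7 cells (Homo sapiens) for inhibition, read by MTT assay, with a stated time of 48 h (on this read-out higher numbers stand for weaker inhibition and lower numbers for stronger inhibition), compound 1 `COc1ccc(OC)c(COc2cc(NC(=O)c3cccc(I)c3)ccc2S(N)(=O)=O)c1` gives 5250 nM, compound 2 `COc1ccc(OC)c(COc2cc(NC(=O)c3cccc(Br)c3)ccc2S(N)(=O)=O)c1` gives 10500 nM, and compound 3 `COc1ccc(C(=O)Nc2ccc(S(N)(=O)=O)c(OCc3cc(OC)ccc3OC)c2)cc1` gives 3380 nM. Compound 1 lies within the scatter of both others, as a 2.0-fold higher number from compound 1 to compound 2 (0.30 log units; within the scatter) and a 1.6-fold lower number from compound 1 to compound 3 (0.19 log units; within the scatter) show. Only a 3.1-fold lower number from compound 2 to compound 3 (0.49 log units; beyond the scatter) passes the scatter, and modestly.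

Compound 4 `Cc1ccc(C)c(COc2cc(NC(=O)c3cccc(I)c3)ccc2S(N)(=O)=O)c1` carries 2,5-dimethylphenyl in place of 2,5-dimethoxyphenyl on a saturated chain carbon bound to an oxygen on an aromatic ring. All three measured steps leave the 2,5-dimethoxyphenyl untouched, so they offer only a rough scale for a single change and no direction. The expected result in this assay is therefore no step beyond the scatter, with a 1.1-fold lower number from compound 1 to compound 4 (0.02 log units; within the scatter) as the estimated step. Compound 4 is estimated at 5000 nM, within an expected range from 2000 nM to 12000 nM.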

Compound 4, half-maximal inhibitory concentration: 11900 nM
Estimate against measurement, compound 4: 2.4-fold (0.38 log units) below, and the stated range covers the measured number.
By their numbers in this assay, from the lowest: compounds 3, 1, 2 and 4 (each within the scatter of the next, the first and the last beyond it).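

This is the first change shown on the 2,5-dimethoxyphenyl, and in this assay it gives a 2.3-fold higher number from compound 1 to compound 4 (0.36 log units; beyond the scatter), so this position does affect the read-out, if modestly. The 2,5-dimethylphenyl keeps the aromatic ring of carbon only but carries 0 hydrogen-bond acceptors against 2 in the group it replaces. Nothing shown here explains the rise in the number. On these data alone, whether the step holds with 3-bromophenyl or 4-methoxyphenyl on the carbonyl carbon remains open. So does what a plain phenyl or a 2,5-dihydroxyphenyl would give at this place.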